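This account rests on a few compounds, and the source may have more. Where it says the series, first, only, none or still open, it means among the compounds named here.

Among the measured compounds shown here, in a toxicity assay on Huh-7 cells (Homo sapiens) for cytotoxicity, read by CCK-8 assay, with a stated time of 24 h (a higher number here means that more compound is tolerated, a lower number that less compound is tolerated), compound 2 `COc1cc2oc(-c3ccc(Nc4ccc(F)cc4)cc3)cc(=O)c2c(OC)c1OC` gives 77600 nM, the only actual number among the compounds measured so far. Compound 1 `Cc1ccc(-c2c(O)c(O)c(O)c3c(=O)cc(-c4ccccc4)oc23)cc1` reads > 100000 nM, which is a limit of the assay and not a number. Compound 3 `O=c1cc(-c2ccccc2)oc2c(-c3ccc(F)cc3)c(O)c(O)c(O)c12` reads > 100000 nM, which is also a limit.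

The next structure is compound 4 `COc1cc2oc(-c3ccc(N4CCN(C)CC4)cc3)cc(=O)c2c(OC)c1OC`, and the change is this: 4-methylpiperazin-1-yl in place of (4-fluorophenyl)amino on an aromatic carbon. A 4-methylpiperazin-1-yl group thus replaces the (4-fluorophenyl)amino group on an aromatic carbon, para to a large group.

For the measured compounds named here, the only measured step between close relatives is a step that the two limits leave unreadable from compound 1 to compound 3. It concerns a different exchange, so it offers no size to carry over to this one. With no measured guide, the expectation starts from compound 2 at 77600 nM, and no shift beyond the usual scatter is expected in this assay, in either direction. The expected change is a 1.1-fold lower number from compound 2 to compound 4 (0.04 log units; within the scatter). For compound 4 the estimated value is 70000 nM, with an expected range from 30000 nM to 100000 nM.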

Compound 4, half-maximal cytotoxic concentration: > 100000 nM
Compound 4: a limit, no number; the forecaster's own chance of this, stated with the estimate: 30%; middle value at least 1.4-fold (0.15 log units) from the limit.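

In this assay, putting 4-methylpiperazin-1-yl in place of (4-fluorophenyl)amino on this aromatic carbon, para to a large group, gives an at least 1.2-fold higher number from compound 2 to compound 4 (0.11 log units; that floor lies within the scatter). This is the first step among the compounds shown with any readable size, yet it gives only a floor, so it could reflect no real change or a much larger one. The reading for compound 4 is a limit of the assay and not a number, and it joins the other readings at that ceiling: the limit of > 100000 nM in this assay, at which 3 of the 4 values shown sit.

Going by these compounds, how far the true value of compound 4 lies from that of compound 2 remains open. It is also unknown how this assay would respond to a smaller group at this position, such as a plain amino group, or to a morpholin-4-yl ring.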